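Moving the Thiophene Attachment Point in Compound 3

The source may hold more compounds than are shown below. What is called first, only, known or untested is meant among the compounds shown, and "the series" means these compounds.

Of the compounds shown here, three sharing one core have been tested in an assay on membranes from CHO cells for displacement of a labelled ligand from adenosine receptor A1 (Homo sapiens), read by scintillation counting, with a stated time of 60 min, tested at 1 uM; a lower number here means less inhibition, a higher number more inhibition at the concentration tested (going by the name of the read-out). Among the compounds with values here, compound 1 `CC1=C(C(=O)C2CC2)C(c2ccsc2)NC(=O)N1` gives 2%, and compound 2 `CC1=C(C(=O)NC(C)C)C(c2ccsc2)NC(=O)N1` gives 8%; the single measured step, a number 6 percentage points higher from compound 1 to compound 2 (within the scatter), lies within the scatter. Compound 3 `CC1=C(c2ncc(C)o2)C(c2cccs2)NC(=O)N1` gives 21%, the highest of the three numbers, beyond the scatter above both compound 2 and compound 1. Compound 4 `CC1=C(c2ncc(C)o2)C(c2ccsc2)NC(=O)N1` has not yet been measured. It differs from compound 3 in one place: thiophen-3-yl in place of thiophen-2-yl on a saturated ring carbon. Within the data shown here, none of the measured steps exchanges thiophen-2-yl for thiophen-3-yl, so nothing measured bears directly on this change. Without such a guide, the expected step of a number 1 percentage points lower from compound 3 to compound 4 (within the scatter) in this assay is none beyond the scatter. Compound 4 is therefore estimated at 20%, within 5% to 38%.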

Compound 4, a percentage reported as inhibition, at one concentration (the size of the read-out at that concentration, not a potency): 34%
The estimate for compound 4 lay 14 percentage points below the measured number; the measured number falls inside the stated range.
By their numbers in this assay, from the lowest: compounds 1 and 2 (each within the scatter of the next); then compound 3; then compound 4.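

Joining the thiophene through a different ring atom, with no atoms gained or lost, is enough to move the number on this saturated ring carbon in this assay: a number 13 percentage points higher from compound 3 to compound 4 (beyond the scatter). With thiophen-3-yl in place, 5-methyl-1,3-oxazol-2-yl also outdoes both carbonyl-linked groups on the double-bonded ring carbon, with a number 26 percentage points higher from compound 2 to compound 4 (beyond the scatter) against isopropylcarbamoyl and a number 32 percentage points higher from compound 1 to compound 4 (beyond the scatter) against cyclopropylcarbonyl. No measurement on hand explains the thiophene result.

On these data alone, whether the same thiophene exchange gives a similar step alongside isopropylcarbamoyl or cyclopropylcarbonyl stays open. So does how a phenyl or furan-3-yl group would compare on this ring carbon.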